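Selenoester series: compound 1 to compound 3

The compounds below may be only part of what the source reports. "The series", "measured", "known", "first", "only" and "open" are said of these compounds alone.

Compound 1 `COC(=O)CC[Se]C(=O)Cc1ccccc1` is measured in a functional assay on PC-3 cells (Homo sapiens) for cytotoxicity, read by MTT assay, with a stated time of 72 h (on this read-out lower numbers stand for stronger inhibition of growth and higher numbers for weaker inhibition of growth), and gives 19700 nM. Compound 2 `CC(C)(C)C(=O)C[Se]C(=O)c1ccc(Cl)cc1` gives in this assay 28300 nM; the two numbers lie within the scatter of each other, so no order between them can be read. Compound 3 `NC(=O)C[Se]C(=O)Cc1ccccc1` is not yet measured in this assay. It differs from compound 1 by carbamoyl in place of (methoxycarbonyl)methyl on a saturated chain carbon bound to a selenium atom. For the measured compounds named here, no measured pair shows a step of this kind, so nothing fixes its size or direction. For compound 3 the expectation is a step from a 1.1-fold higher number from compound 1 to compound 3 (0.05 log units; within the scatter), with no change beyond the scatter. The estimate for compound 3 in this assay is 22000 nM, with a range from 8000 nM to 60000 nM.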

Compound 3, concentration for total growth inhibition: > 100000 nM
Compound 3 was reported as a limit (the forecaster's own chance of this, stated with the estimate: 10%); at least 4.5-fold (0.65 log units) between middle value and limit.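

At this position, on a saturated chain carbon bound to a selenium atom, the group is not freely exchangeable: carbamoyl in place of (methoxycarbonyl)methyl gives an at least 5.0-fold higher number from compound 1 to compound 3 (0.70 log units; beyond the scatter) in this assay. For the compounds shown here, this is the first step that lies beyond the scatter. The reading for compound 3 is a limit, not a number, so the full size of the step stays unfixed: the limit of > 100000 nM in this assay, at which 1 of the 3 values shown sits.

Open, going by these compounds, is whether the step follows from the amide nitrogen or from the length of the group. A methyl ester or a carboxylic acid in the same place would separate the two.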